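The source may hold more compounds than are shown below. What is called first, only, known or untested is meant among the compounds shown, and "the series" means these compounds.

Measured compounds:
- compound 1 `CCCCCCCCCCCCCCNC(=O)[C@H](CO)/N=C/c1cccc(OC)c1`, 77300 nM
- compound 2 `CCCCCCCCCCCCCCNC(=O)[C@H](CO)/N=C/c1ccccc1[N+](=O)[O-]`, 82600 nM
- compound 3 `CCCCCCCCCCCCCCNC(=O)[C@H](CO)/N=C/c1cccc(Cl)c1`, 77000 nM

These values come from an ADME assay on HEK293 cells (Homo sapiens) for cytotoxicity; a higher number here means a weaker inhibitor, a lower number a stronger inhibitor. Compound 1 stands second highest of the three, yet its distances to compound 3 a 1.0-fold lower number from compound 1 to compound 3 (0.00 log units; within the scatter) and to compound 2 a 1.1-fold higher number from compound 1 to compound 2 (0.03 log units; within the scatter) both lie within the scatter, as does the gap from compound 2 to compound 3 a 1.1-fold lower number from compound 2 to compound 3 (0.03 log units; within the scatter). Compound 4 `CCCCCCCCCCCCCCNC(=O)[C@H](CO)/N=C/c1ccc(C)cc1` keeps the shared core of compound 1 and changes only the aromatic group: 4-methylphenyl in place of 3-methoxyphenyl on a carbon with a double bond to nitrogen. Every measured step swaps one such aromatic group for another and none moves the number beyond the scatter, so no real shift is expected here either. For compound 4 the expected step is a 1.0-fold higher number from compound 1 to compound 4 (0.00 log units; within the scatter), and the estimate in this assay is 78000 nM, in the range 45000 nM to 135000 nM.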

Compound 4, half-maximal inhibitory concentration: 47300 nM
The estimate for compound 4 lay 1.6-fold (0.22 log units) above the measured number; the measured number falls inside the stated range.
By their numbers in this assay, from the lowest: compounds 4, 3, 1 and 2 (each within the scatter of the next).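

In this assay, placing 4-methylphenyl on the carbon with a double bond to nitrogen gives a 1.6-fold lower number from compound 1 to compound 4 (0.21 log units; within the scatter), a 1.6-fold lower number from compound 3 to compound 4 (0.21 log units; within the scatter) and a 1.7-fold lower number from compound 2 to compound 4 (0.24 log units; within the scatter). This group has no hydrogen-bond acceptor, whereas 3-methoxyphenyl has one, yet losing that acceptor in this swap gives no step beyond the scatter. No measurement shown here explains the numbers. From the compounds shown here alone, whether an amine or a carboxylic acid on the aromatic ring would move the number beyond the scatter remains open. So does the effect of a shorter chain on the shared core.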